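Swapping 4-fluorophenyl for 3-nitrophenyl: what to expect

A few compounds are considered here, and "the series" means these few. Any claim that something is new, unique, unknown or untested is made for them only; others in the source may bear on it.

Measured in a functional assay on MCF7 cells (Homo sapiens) for cytotoxicity, read by MTT assay, with a stated time of 72 h (on this read-out higher numbers stand for weaker inhibition and lower numbers for stronger inhibition), as follows
Compound 1 `CNC(=O)c1cc(Oc2ccc(C(=O)/C=C/c3ccc(Br)cc3)cc2)ccn1` gives > 50000 nM (a limit of the assay, not a number)
Compound 2 `CNC(=O)c1cc(Oc2ccc(C(=O)/C=C/c3ccc(C#N)cc3)cc2)ccn1` gives 9520 nM
Compound 3 `CNC(=O)c1cc(Oc2ccc(C(=O)/C=C/c3ccc(F)cc3)cc2)ccn1` gives 28500 nM

Of the two exact numbers in this assay compound 3 holds the higher one, and compound 2 is its nearest neighbour, with a 3.0-fold higher number from compound 2 to compound 3 (0.48 log units; beyond the scatter) separating them.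

The next compound is compound 4 `CNC(=O)c1cc(Oc2ccc(C(=O)/C=C/c3cccc([N+](=O)[O-])c3)cc2)ccn1` and its change is 3-nitrophenyl in place of 4-fluorophenyl on a double-bonded chain carbon bound to a double-bonded chain carbon in the shared core. Among the compounds with values here, three measured steps bear on this, all swaps of one group on that same phenyl ring. The clearest are an at least 5.2-fold lower number from compound 1 to compound 2 (0.72 log units; beyond the scatter) and a 3.0-fold higher number from compound 2 to compound 3 (0.48 log units; beyond the scatter). The third, an at least 1.7-fold lower number from compound 1 to compound 3 (0.24 log units; that floor lies within the scatter), rests on a limit. None of them tests a nitro group or a 3-substituted phenyl, so only a modest step is a fair expectation, leaning slightly lower since the swap in compound 2 at 9520 nM shows that this ring can tolerate a lower number.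

The expected step is small, namely a 1.8-fold lower number from compound 3 to compound 4 (0.25 log units; within the scatter), and it may not stand clear of the scatter. For compound 4 the estimated value is 16000 nM, with an expected range of 5000 nM to 50000 nM in this read-out.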

Compound 4, half-maximal inhibitory concentration: > 50000 nM
Compound 4: a limit, no number; the forecaster's own chance of this, stated with the estimate: 20%; at least 3.1-fold (0.49 log units) between middle value and limit.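

Changing to 3-nitrophenyl gives compound 4 a limit, not a number, the same kind of result as compound 1: the limit of > 50000 nM in this assay, at which 2 of the 4 values shown sit.

Against 4-fluorophenyl, the change gives an at least 1.7-fold higher number from compound 3 to compound 4 (0.24 log units; that floor lies within the scatter), so this step alone does not set the two compounds apart, whereas against 4-cyanophenyl it gives an at least 5.2-fold higher number from compound 2 to compound 4 (0.72 log units; beyond the scatter), showing that the lower number of compound 2 does not extend to this new group. The step between compound 1 and compound 4 cannot be read, as both results are limits.

Compound 4 differs from compound 3 in both the group and its place on the phenyl ring, and the compounds shown cannot separate those two changes. From the compounds shown here alone, how an amine or a carboxylic acid on this ring would read in this assay also remains open.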